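Replacing (naphthalen-2-yl)methyl with pyrimidin-5-yl in compound 1

The source may report more compounds than this note shows. Statements on the series, on what has been measured and on what is new or still open speak of the compounds shown alone.

In a functional assay on SGC-7901 cells (Homo sapiens) for inhibition, read by MTT assay, with a stated time of 72 h (a lower number here means a stronger inhibitor of growth, a higher number a weaker inhibitor of growth), compound 1 (`O[C@H](COCCOC[C@@H](O)Cc1cn(Cc2ccc3ccccc3c2)nn1)Cc1ccc(-c2ccccc2)cc1`) gives 12100 nM. Compound 3 (`O[C@H](COCCOC[C@@H](O)Cc1cn(Cc2cccc(-c3ccccc3)c2)nn1)Cc1ccc(-c2ccccc2)cc1`) gives 10600 nM, and these two values lie within the scatter of each other. Together they form the upper end of the three numbers measured so far. Compound 2 (`CC1=C(CCCCCCCCCCn2cc(C[C@H](O)COCCOC[C@@H](O)Cc3ccc(-c4ccccc4)cc3)nn2)C(=O)c2ccccc2C1=O`), which carries a different group on the same aromatic nitrogen, stands well apart at 390 nM.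

The next compound to be tested is compound 4 (`O[C@H](COCCOC[C@@H](O)Cc1cn(-c2cncnc2)nn1)Cc1ccc(-c2ccccc2)cc1`), with pyrimidin-5-yl in place of (naphthalen-2-yl)methyl on an aromatic nitrogen.

Among the compounds with values here, only one measured step touches this part of the structure. In that step, 3-phenylphenyl replaces naphthalen-2-yl, giving a 1.1-fold lower number from compound 1 to compound 3 (0.06 log units; within the scatter), which is within the scatter. Within the data shown here, that change keeps the saturated chain carbon, however, whereas compound 4 loses it, so no measured step matches the new change directly. The low value of compound 2 shows that this position can matter, but compound 2 carries a very different group and offers little guidance for a pyrimidin-5-yl. A step beyond the scatter is therefore not expected in this assay, although a modest rise would not surprise. The expected change is a 1.2-fold higher number from compound 1 to compound 4 (0.09 log units; within the scatter). For compound 4 the estimated value is 15000 nM, with an expected range from 6000 nM to 40000 nM.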

Compound 4, concentration for 50% growth inhibition: > 100000 nM
Compound 4: no number, only a limit; the forecaster's own chance of this, stated with the estimate: 15%; middle value at least 6.6-fold (0.82 log units) from the limit.
By their numbers in this assay, from the lowest: compound 2; then compounds 3 and 1 (each within the scatter of the next). At a limit, above all of these: compound 4.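

In this assay compound 4 reads > 100000 nM, which is a limit of the assay and not a number: the limit of > 100000 nM in this assay, at which 1 of the 4 values shown sits. Within the data shown here, putting pyrimidin-5-yl in place of (naphthalen-2-yl)methyl on the aromatic nitrogen gives an at least 8.2-fold higher number from compound 1 to compound 4 (0.91 log units; beyond the scatter), whereas the only earlier step at this position, 3-phenylphenyl in place of naphthalen-2-yl, gave a 1.1-fold lower number from compound 1 to compound 3 (0.06 log units; within the scatter), so this position is not indifferent to every aryl group placed there. Before this result, the values for changes at this nitrogen ran from compound 2 at 390 nM to compound 1 at 12100 nM, and the new step shows that growth inhibition can also fall away well past the upper end of that range.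

The change removes the saturated chain carbon, reduces the number of heavy atoms and brings in ring nitrogens all at once, and the compounds shown do not tell these apart. As far as these compounds go, a plain phenyl group directly on the aromatic nitrogen, or a pyrimidin-5-ylmethyl group that keeps the chain carbon, would be needed to separate them, and the effect of an amine at the end of a longer chain on this nitrogen also remains open.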